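The source may hold more compounds than are shown below. What is called first, only, known or untested is meant among the compounds shown, and "the series" means these compounds.

Compound 1, `Clc1ccc(Cc2nnc(SCc3ccccc3)[nH]2)c(Oc2ccccc2Cl)c1`, gives 122% in a functional assay on the whole organism (strain NMRI) with Mus musculus as the target, with a stated time of 60 min, at a dose of 10 mg/kg by the intraperitoneal route; a lower number here means a weaker effect, a higher number a stronger effect of the compound at the dose given. Compound 2, `Fc1ccccc1Oc1cc(Cl)ccc1Cc1nnc(SCc2ccccc2)[nH]1`, differs from it in one place, (fluoro in place of chloro on an aromatic carbon), and gives 169%; the measured step of a number 47 percentage points higher from compound 1 to compound 2 (beyond the scatter). Compound 3, `Nc1nnc(Cc2ccc(Cl)cc2Oc2ccccc2Cl)o1`, carries a different core, and how its core differs from that of compound 1 is not broken down here; in this assay compound 3 gives 132%, which sits within the usual scatter of the number for compound 1 and clearly below that for compound 2. Compound 4, `Nc1nnc(Cc2ccc(Cl)cc2Oc2ccccc2F)o1`, differs from compound 3 by fluoro in place of chloro on an aromatic carbon, the same change as from compound 1 to compound 2, at the same kind of place. Because a number 47 percentage points higher from compound 1 to compound 2 (beyond the scatter), the step of a number 33 percentage points higher from compound 3 to compound 4 (beyond the scatter) is expected, with more uncertainty since the core differs. Compound 4 is expected to give 165% in this assay, between 130% and 200%.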

Compound 4, a percentage reported as activity, at one dose (the size of the read-out at that dose, not a potency): 129%
Beside the measured number, compound 4's estimate is 36 percentage points above it; the measured number lies below the stated range.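

In this assay, fluoro in place of chloro on the core of compound 3 gives a number 3 percentage points lower from compound 3 to compound 4 (within the scatter), so the gain seen on the core of compound 1 does not carry over to this core. The two pairs shown therefore give different results for the same change: the same change on two cores in this assay, a number 47 percentage points higher (beyond the scatter) from compound 1 to compound 2 and a number 3 percentage points lower (within the scatter) from compound 3 to compound 4, 50 percentage points apart, beyond the scatter of two such steps This shows that the effect of this change depends on the core in these two pairs, but it does not show why, and two pairs give no rule for any further core.

The compounds shown leave open how a methyl or methoxy group would behave at the same place on each core. They also leave open whether a third core would follow either pair.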